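Swapping a Bridged Amine for a Methylpyrrolidine

The compounds below may be only part of what the source reports. "The series", "measured", "known", "first", "only" and "open" are said of these compounds alone.

Three compounds have been measured in an assay on isolated protein for displacement of a labelled ligand from melanin-concentrating hormone receptor 1 (Homo sapiens); a lower number here means a stronger inhibitor, a higher number a weaker inhibitor:
compound 1, `O=C(CCc1ccc(C(F)(F)F)cc1)Nc1ccc2nc(N3CCC(c4ccccc4)C3)ccc2c1`, gives 25 nM;
compound 2, `O=C(CCc1ccc(C(F)(F)F)cc1)Nc1ccc2nc(N3CC4CCC3C4)ccc2c1`, gives 1 nM;
compound 3, `O=C(CCc1ccc(C(F)(F)F)cc1)Nc1ccc2nc(N3CC4CCC3CC4)ccc2c1`, gives 3 nM.

Compound 3 stands second highest of the three numbers. Its nearest neighbour is compound 2, with a 3.0-fold higher number from compound 2 to compound 3 (0.48 log units; beyond the scatter); its furthest is compound 1, with an 8.3-fold lower number from compound 1 to compound 3 (0.92 log units; beyond the scatter).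

Compound 4 is `CC1CCCN1c1ccc2cc(NC(=O)CCc3ccc(C(F)(F)F)cc3)ccc2n1`. It differs from compound 3 in one place: a group of 6 heavy atoms (5 carbon, 1 nitrogen; one five-membered non-aromatic ring with 1 hetero atom) in place of a group of 8 heavy atoms (7 carbon, 1 nitrogen; 2 six-membered non-aromatic rings with 1 hetero atom each), on an aromatic carbon. The two steps that replaced the group with a phenyl ring by a smaller cyclic amine both lowered the number, a 25-fold lower number from compound 1 to compound 2 (1.40 log units; beyond the scatter) strongly and an 8.3-fold lower number from compound 1 to compound 3 (0.92 log units; beyond the scatter) modestly, and of the two smaller amines the one with fewer atoms, in compound 2, gave the lower number. Compound 4 carries an amine smaller than either, so its number is expected to stay near compound 3 or drop somewhat, an expected no change at the digits printed from compound 3 to compound 4 (within the scatter) in this assay. Compound 4 is therefore estimated at 3 nM, within 1 nM to 10 nM.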

Compound 4, half-maximal inhibitory concentration: 5 nM
Beside the measured number, compound 4's estimate is 1.7-fold (0.22 log units) below it; low and high end bracket the measured number.
By their numbers in this assay, from the lowest: compound 2; then compounds 3 and 4 (each within the scatter of the next); then compound 1.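

In this assay, a single ring carrying one methyl stays level with the two-ring amine of compound 3 (a 1.7-fold higher number from compound 3 to compound 4 (0.22 log units; within the scatter)), so at this position next to the ring nitrogen a second ring is not needed to stay in this range. The five-membered bridged amine of compound 2 still keeps a real edge (a 5.0-fold higher number from compound 2 to compound 4 (0.70 log units; beyond the scatter)), and 2-methylpyrrolidin-1-yl also gives a lower number than 3-phenylpyrrolidin-1-yl (a 5.0-fold lower number from compound 1 to compound 4 (0.70 log units; beyond the scatter)), so all three smaller amines now sit below compound 1. Nothing measured here explains these differences.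

It remains open what the methyl itself contributes, since the plain pyrrolidin-1-yl ring is not among these compounds. A piperidine ring or an open-chain amine such as dimethylamino at the same place could also show whether any ring is needed at all.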